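Diethylamino to Pyrrolidin-1-yl on the Carbonyl Carbon

The source may hold more compounds than are shown below. What is called first, only, known or untested is meant among the compounds shown, and "the series" means these compounds.

Compound 1, `Cc1ccc(S(=O)(=O)Nc2cccc(-c3nc(-c4ccc(NC(=O)c5cccnc5)cc4Cl)no3)c2)cc1`, gives in a functional assay on MDA-MB-231 cells (Homo sapiens) for antiproliferative activity, read by MTT assay, with a stated time of 72 h (on this read-out lower numbers stand for stronger inhibition and higher numbers for weaker inhibition), the value > 10000 nM, a limit of the assay.
Compound 2, `O=C(Nc1ccc(-c2noc(-c3cccc(NS(=O)(=O)c4ccc(C(F)(F)F)cc4)c3)n2)c(Cl)c1)c1cccnc1`, gives in this assay the value > 10000 nM, also a limit.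
Compound 3, `CCN(CC)C(=O)Nc1ccc(S(=O)(=O)Nc2cccc(-c3nc(-c4ccc(NC(=O)c5cccnc5)cc4Cl)no3)c2)cc1`, gives in this assay the value 8700 nM.

Among the measured compounds shown here, compound 3 thus holds the only number among the three; the other two values sit at the limit (the limit of > 10000 nM in this assay, at which 2 of the 3 values shown sit). Compound 4, `O=C(Nc1ccc(-c2noc(-c3cccc(NS(=O)(=O)c4ccc(NC(=O)N5CCCC5)cc4)c3)n2)c(Cl)c1)c1cccnc1`, differs from compound 3 by pyrrolidin-1-yl in place of diethylamino on a carbonyl carbon. The measured steps change the group on an aromatic carbon instead: an at least 1.1-fold lower number from compound 1 to compound 3 (0.06 log units; that floor lies within the scatter), an at least 1.1-fold lower number from compound 2 to compound 3 (0.06 log units; that floor lies within the scatter), and a step that the two limits leave unreadable from compound 1 to compound 2. For the measured compounds named here, none of them touches the carbonyl carbon, so no step in this assay beyond the scatter is expected, and the estimated step is a 1.1-fold lower number from compound 3 to compound 4 (0.04 log units; within the scatter). Compound 4 is therefore expected at 8000 nM, between 4000 nM and 20000 nM.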

Compound 4, half-maximal inhibitory concentration: 5800 nM
For compound 4 the middle estimate is 1.4-fold (0.14 log units) above the measured one, and the stated range covers the measured number.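

In this assay pyrrolidin-1-yl on the carbonyl carbon gives a 1.5-fold lower number from compound 3 to compound 4 (0.18 log units; within the scatter) and so, at this position, closing the diethylamino group into a ring gives a value that cannot be told apart from that of compound 3. The steps that bring in the whole ((pyrrolidin-1-yl)carbonyl)amino group on the aromatic carbon, an at least 1.7-fold lower number from compound 2 to compound 4 (0.23 log units; that floor lies within the scatter) and an at least 1.7-fold lower number from compound 1 to compound 4 (0.23 log units; that floor lies within the scatter), are floors only, because their starting values are limits: the limit of > 10000 nM in this assay, at which 2 of the 4 values shown sit.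

The compounds shown leave open whether piperidin-1-yl or morpholin-4-yl on the same carbonyl carbon would move the number beyond the scatter.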